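A few compounds are considered here, and "the series" means these few. Any claim that something is new, unique, unknown or untested is made for them only; others in the source may bear on it.

Measured compounds:
compound 2, `NCc1cc(Oc2cccc(C(=O)N3CC[C@@H](N)C3)c2)nc(C(F)(F)F)c1`, in an ADME assay on the whole organism (plasma, Mus musculus) for pharmacokinetics, read by LC-MS, at a dose of 30 mg/kg by the oral route (on this read-out lower numbers stand for lower exposure and higher numbers for higher exposure at the dose given), compound 2 gives 670 nM;
compound 3, `NCc1cc(Oc2cccc(C(=O)N3CC[C@@H](O)C3)c2)nc(C(F)(F)F)c1`, compound 3 gives 5130 nM;
compound 1, `NCc1cc(Oc2cccc(C(=O)NCc3cc4ccccc4s3)c2)nc(C(F)(F)F)c1`, in this assay compound 1 gives "not determined" (no result reported), so no result was reported for it.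

On the two numbers available, compound 3 stands highest; its nearest neighbour is compound 2, and the change a 7.7-fold higher number from compound 2 to compound 3 (0.88 log units; beyond the scatter) lies beyond the scatter. Compound 4, `CONC(=O)c1cccc(Oc2cc(CN)cc(C(F)(F)F)n2)c1`, has not been measured. It differs from compound 3 in one place: methoxyamino in place of 3-hydroxypyrrolidin-1-yl on a carbonyl carbon. Going by the values given here, no measured step covers this kind of change; the only step in hand, a 7.7-fold higher number from compound 2 to compound 3 (0.88 log units; beyond the scatter), concerns a different alteration on the same ring and so bears only loosely on it, showing that this part of the molecule can move the exposure by a modest amount. Among the compounds with values here, with no closer precedent, a step of no clear direction is expected, most likely within the scatter, and compound 4 is estimated to give 3000 nM in this assay, between 800 nM and 12000 nM. The expected change a 1.7-fold lower number from compound 3 to compound 4 (0.23 log units; within the scatter) is therefore small, with a wide band of uncertainty.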

Compound 4, maximal plasma concentration: 630 nM
Estimate against measurement, compound 4: 4.8-fold (0.68 log units) above, outside the stated range (below it).
By their numbers in this assay, from the lowest: compounds 4 and 2 (each within the scatter of the next); then compound 3.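

In this assay, methoxyamino in place of 3-hydroxypyrrolidin-1-yl on the carbonyl carbon gives an 8.1-fold lower number from compound 3 to compound 4 (0.91 log units; beyond the scatter), so this position responds to exchanging the whole group and not only to the change on the saturated ring. Methoxyamino in place of 3-aminopyrrolidin-1-yl gives a 1.1-fold lower number from compound 2 to compound 4 (0.03 log units; within the scatter), which leaves those two groups indistinguishable on this read-out and compound 3 alone standing apart from both others. Nothing available explains why the exposure differs among these compounds.

On these data alone, it remains open whether the higher number of compound 3 depends on the hydroxy group alone or on the hydroxy group carried by the ring. An unsubstituted pyrrolidin-1-yl group or an open-chain 2-hydroxyethylamino group on the carbonyl carbon would be needed to separate those two readings.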